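Swapping a Cyclohexyl Ring for a Benzyl Group

A few compounds are considered here, and "the series" means these few. Any claim that something is new, unique, unknown or untested is made for them only; others in the source may bear on it.

In a functional assay on HeLa cells (Homo sapiens) for inhibition, read by CCK-8 assay, with a stated time of 48 h (on this read-out lower numbers stand for stronger inhibition and higher numbers for weaker inhibition), compound 1 (`O=C(NCCNS(=O)(=O)c1ccc(-c2ccccc2O[C@H]2CC[C@H](O)CC2)s1)Nc1cc(C(F)(F)F)cc(C(F)(F)F)c1`) gives > 20000 nM, which is a limit of the assay and not a number. Compound 2 (`O=C(Nc1cccc([N+](=O)[O-])c1)N1CCN(S(=O)(=O)c2sccc2-c2ccccc2Oc2ccc(O)c(O)c2)CC1`) gives > 20000 nM, which is also a limit. Among the measured compounds shown here, compound 1 therefore stands with the only other tested compound, and the whole picture so far is the limit of > 20000 nM in this assay, at which 2 of the 2 values shown sit. For the measured compounds named here, no measured compound yet offers a number to compare against.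

Compound 3 (`O=C(NCCNS(=O)(=O)c1ccc(-c2ccccc2OCc2cccc(O)c2)s1)Nc1cc(C(F)(F)F)cc(C(F)(F)F)c1`) keeps the core of compound 1 and changes one group: 3-hydroxybenzyl in place of 4-hydroxycyclohexyl on an oxygen on an aromatic ring. Going by the values given here, with no measured step as a guide, only a modest shift towards stronger inhibition is expected, the estimated step being an at least 1.1-fold lower number from compound 1 to compound 3 (0.04 log units; that floor lies within the scatter). Compound 3 may well stop at the same limit. For compound 3 the estimated value is 18000 nM, with an expected range from 5000 nM to 40000 nM.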

Compound 3, half-maximal inhibitory concentration: 17300 nM
Estimate against measurement, compound 3: 1.0-fold (0.02 log units) above; low and high end bracket the measured number.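

Among the compounds shown here, at this oxygen on an aromatic ring, the 3-hydroxybenzyl group yields the first true number in the set: in this assay, compound 3 gives 17300 nM. Compound 1 gives > 20000 nM, which is a limit of the assay and not a number. The exchange of 4-hydroxycyclohexyl for 3-hydroxybenzyl can therefore be read only as an at least 1.1-fold lower number from compound 1 to compound 3 (0.06 log units; that floor lies within the scatter), so it shows no clear gain, and the overall picture is still dominated by one value: the limit of > 20000 nM in this assay, at which 2 of the 3 values shown sit.

As far as these compounds go, the size of any real difference between the two groups stays open, since only a floor can be read. Also open, from the compounds shown here alone, is how this position would respond to a benzyl group carrying an amine or a carboxylic acid in place of the hydroxyl, or to a longer chain between the oxygen and the ring.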